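The source may hold more compounds than are shown below. What is called first, only, known or untested is meant among the compounds shown, and "the series" means these compounds.

Measured in a functional assay on A-375 cells (Homo sapiens) for antiproliferative activity, read by MTT assay, with a stated time of 24 h; a higher number here means a weaker inhibitor, a lower number a stronger inhibitor:
- Compound 1 `C#CCOc1ccc2c(=O)c(-c3cc(OC)c(OC)cc3OC)coc2c1`: 3680 nM
- Compound 2 `COc1cc(OC)c(-c2coc3cc(OCc4ccccc4F)ccc3c2=O)cc1OC`: 2100 nM
- Compound 3 `COc1cc(OC)c(-c2coc3cc(OCc4ccc(Br)cc4)ccc3c2=O)cc1OC`: 1000 nM

Compound 3 has the lowest number of the three, and its steps to both others lie beyond the scatter. Compound 4 `COc1cc(OC)c(-c2coc3cc(OCc4ccccc4C#N)ccc3c2=O)cc1OC` keeps the shared core and alters one group: 2-cyanophenyl in place of 4-bromophenyl on a saturated chain carbon bound to an oxygen on an aromatic ring. The closest evidence is a 2.1-fold lower number from compound 2 to compound 3 (0.32 log units; beyond the scatter), a modest step that exchanged 2-fluorophenyl for 4-bromophenyl. The step of a 3.7-fold lower number from compound 1 to compound 3 (0.57 log units; beyond the scatter) is also modest, whereas a 1.8-fold lower number from compound 1 to compound 2 (0.24 log units; within the scatter) stays within the scatter. Going by the values given here, no cyano-bearing compound has been measured, so 2-fluorophenyl offers only an approximate guide. A modest rise in this assay is therefore expected, towards the level of compound 2 at 2100 nM. The estimated change is a 1.9-fold higher number from compound 3 to compound 4 (0.28 log units; within the scatter). Compound 4 is expected at 1900 nM, within an estimated range of 850 nM to 4300 nM.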

Compound 4, half-maximal inhibitory concentration: 990 nM
For compound 4 the middle estimate is 1.9-fold (0.28 log units) above the measured one, within the range that was stated.
By their numbers in this assay, from the lowest: compounds 4 and 3 (each within the scatter of the next); then compounds 2 and 1 (each within the scatter of the next).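

In this assay the 2-cyanophenyl group on the saturated chain carbon reads level with the 4-bromophenyl group of compound 3 (a 1.0-fold lower number from compound 3 to compound 4 (0.00 log units; within the scatter)), so a ring bearing a nitrile serves this position as well as that bromine-bearing ring does. Cyano in place of fluoro on an aromatic carbon gives a step beyond the scatter (a 2.1-fold lower number from compound 2 to compound 4 (0.33 log units; beyond the scatter)), and the step from the ethynyl group is larger (a 3.7-fold lower number from compound 1 to compound 4 (0.57 log units; beyond the scatter)). No measured evidence bears on why these values fall as they do. As far as these compounds go, what remains open is how an amine, a carboxylic acid or a longer chain would read in this assay at this position.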